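A Methyl Added to a Pyridazine on an Inactive Core

The source may report more compounds than this note shows. Statements on the series, on what has been measured and on what is new or still open speak of the compounds shown alone.

Compound 1 `O=C(Nc1nc2ccc(F)cc2s1)N1CCN(c2ccc(Cl)nn2)CC1`: in an assay on HEK293 cells for inhibition of transient receptor potential cation channel subfamily V member 1 (Homo sapiens), read by FLIPR (on this read-out higher numbers stand for weaker inhibition and lower numbers for stronger inhibition), compound 1 gives > 10000 nM, which is a limit of the assay and not a number.
Compound 2 `Cc1cc(N2CCN(C(=O)Nc3nc4ccc(F)cc4s3)CC2)nnc1Cl`: in this assay compound 2 gives > 10000 nM, again a limit of the assay.
Compound 3 `O=C(Nc1nc2ccc(F)cc2s1)N1CCN(c2cccnn2)CC1`: in this assay compound 3 gives > 10000 nM, also a limit of the assay.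

All three compounds share one core and differ only in the substituents on the pyridazin-3-yl ring attached to the piperazine nitrogen. Compound 3 stands, like the other two, at the limit of > 10000 nM in this assay, at which 3 of the 3 values shown sit, so no ranking among them is possible. The steps between them cannot be read: a step that the two limits leave unreadable from compound 1 to compound 2, a step that the two limits leave unreadable from compound 1 to compound 3 and a step that the two limits leave unreadable from compound 2 to compound 3 all remain unreadable because each value sits at the limit of > 10000 nM in this assay, at which 3 of the 3 values shown sit.

Compound 4 `Cc1cnnc(N2CCN(C(=O)Nc3nc4ccc(F)cc4s3)CC2)c1` differs from compound 3 by methyl in place of hydrogen on an aromatic carbon. Among the compounds with values here, the only measured step of the same kind is the one from compound 1 to compound 2, which was a step that the two limits leave unreadable from compound 1 to compound 2 and gives no guidance on size or direction. With nothing pointing away from the limit, compound 4 is expected to show no step beyond the scatter, a step that the limit leaves unreadable from compound 3 to compound 4. Compound 4 is therefore estimated at 15000 nM, with a range from 5000 nM to 50000 nM, most likely reported again only as a limit.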

Compound 4, half-maximal inhibitory concentration: > 10000 nM
Compound 4: a limit, no number; the forecaster's own chance of this, stated with the estimate: 85%; the middle value lies beyond the limit too.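

In this assay compound 4 gives > 10000 nM, a limit of the assay and not a number, so none of its steps to compound 1, compound 2 or compound 3 can be read: the limit of > 10000 nM in this assay, at which 4 of the 4 values shown sit. The compounds shown leave open whether any substituent on the pyridazin-3-yl ring of this shared core gives a measurable inhibition.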